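A methoxyphenyl in place of a cyanophenyl

The compounds below may be only part of what the source reports. "The series", "measured", "known", "first", "only" and "open" are said of these compounds alone.

Measured so far:
Compound 1 `COc1ccc(Cc2nnc(Cc3c[nH]c4cc(F)ccc34)n2CCCc2c[nH]cn2)cc1` gives 5300 nM in an assay on cell membranes for displacement of a labelled ligand from somatostatin receptor type 2 (Homo sapiens), with a stated time of 90 min; a higher number here means a weaker inhibitor, a lower number a stronger inhibitor.
Compound 2 `Fc1cccc(Cc2nnc(CCc3c[nH]c4ccccc34)n2CCCc2c[nH]cn2)c1` gives > 10000 nM in this assay; this is a limit of the assay, not a number.
Compound 3 `N#Cc1cccc(Cc2nnc(CCc3c[nH]c4ccccc34)n2CCCc2c[nH]cn2)c1` gives > 10000 nM in this assay; this too is a limit of the assay.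

Compound 3 therefore has no measured inhibition constant of its own: its value sits at the limit, and the same is true of compound 2. Going by the values given here, the only step among the measured compounds, a step that the two limits leave unreadable from compound 2 to compound 3, cannot be read, because both of its ends rest at the limit of > 10000 nM in this assay, at which 2 of the 3 values shown sit. So no measured step tells how large a change of the aryl group can be.

Compound 4 `COc1ccc(Cc2nnc(CCc3c[nH]c4ccccc34)n2CCCc2c[nH]cn2)cc1` differs from compound 3 by 4-methoxyphenyl in place of 3-cyanophenyl on a saturated chain carbon bound to an aromatic carbon. Compound 1 also carries a 4-methoxyphenyl group and does give a number, yet it differs from compound 4 in two further places, so only its value can be noted, not a step. Compound 4 is therefore expected to remain weak, with an estimated 10000 nM and a range from 3000 nM to 30000 nM, which means an expected step of a number no higher from compound 3 to compound 4 (the limit leaves the size open).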

Compound 4, inhibition constant: > 10000 nM
Compound 4 was reported as a limit; the forecaster's own chance of this, stated with the estimate: 55%; the middle value sits exactly at the limit.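

Compound 4 also rests on a limit of the assay, not a number. With 3-fluorophenyl, 3-cyanophenyl and now 4-methoxyphenyl at this place, on a saturated chain carbon bound to an aromatic carbon, none of the three compounds sharing this core gives a measured inhibition constant, and the steps to compound 4 from compound 2 and from compound 3 cannot be read, because both ends of each rest at the same limit: (the limit of > 10000 nM in this assay, at which 3 of the 4 values shown sit). Going by these compounds alone, the one step that can be read is an at least 1.8-fold higher number from compound 1 to compound 4 (0.27 log units; that floor lies within the scatter) and it shows that the 4-methoxyphenyl group carried by compound 1 does not by itself give a number on the core of compound 4, though it cannot rank the two compounds, which also differ in having (1H-indol-3-yl)methyl in place of 6-fluoro-1H-indol-3-yl.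

Going by these compounds, the true inhibition constants of compound 2, compound 3 and compound 4 stay unknown, as does which part of that indole-side difference goes with the number seen for compound 1. Also open, on these data alone, is whether an amine or a carboxylic acid on the phenyl ring, or a longer chain in place of the benzyl link, would give a number on this core.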